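Cytotoxicity notes: the step from compound 2 to compound 3

This account rests on a few compounds, and the source may have more. Where it says the series, first, only, none or still open, it means among the compounds named here.

Values so far in a functional assay on SF-268 cells (Homo sapiens) for cytotoxicity, read by MTT assay, with a stated time of 3 days; on this read-out lower numbers stand for stronger inhibition and higher numbers for weaker inhibition
compound 1 `N#Cc1c(NN)nc(SCc2nc3ccccc3[nH]2)nc1-c1ccccc1` at 2.77 nM
compound 2 `CCNc1nc(SCc2nc3ccccc3[nH]2)nc(-c2ccccc2)c1C#N` at 7.35 nM

Compound 2 stands at 7.35 nM as the higher of the two numbers. Compound 3 `N#Cc1c(NNC(N)=S)nc(SCc2nc3ccccc3[nH]2)nc1-c1ccccc1` carries one change on the shared core: a group of 4 heavy atoms (1 carbon, 2 nitrogen, 1 sulfur; no ring) in place of a group of 2 heavy atoms (2 carbon; no ring), on a nitrogen on an aromatic ring and nothing else differs. Going by the values given here, the only measured step at this place is a 2.7-fold higher number from compound 1 to compound 2 (0.42 log units; beyond the scatter) and it is modest. Compound 1 at 2.77 nM is the sole lower reference, and no group like the entering one has been measured yet. A modest step towards a lower number is therefore expected in this assay with wide margins. The expected step is a 1.5-fold lower number from compound 2 to compound 3 (0.17 log units; within the scatter) on this estimate. For compound 3 the estimated value is 5 nM within an expected range from 1.5 nM to 18 nM on this read-out.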

Compound 3, half-maximal inhibitory concentration: 3.37 nM
Beside the measured number, compound 3's estimate is 1.5-fold (0.17 log units) above it; the range from low to high includes it.
By their numbers in this assay, from the lowest: compounds 1 and 3 (each within the scatter of the next); then compound 2.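

In this assay the group entering on the nitrogen on an aromatic ring, with its 2 hydrogen-bond donors and 1 hydrogen-bond acceptor, gives (a 2.2-fold lower number from compound 2 to compound 3 (0.34 log units; beyond the scatter)), so this position takes a group of 4 heavy atoms without the number rising. Compared on the amine nitrogen of compound 1, the added group of 3 heavy atoms gives (a 1.2-fold higher number from compound 1 to compound 3 (0.09 log units; within the scatter)), and within the scatter compound 1 and compound 3 cannot be told apart. No measurement on hand bears on either step.

Open, going by these compounds, is whether the sulfur of the entering group counts for anything, which the oxygen counterpart, a urea, would test, and whether an acetyl group on the same amine nitrogen reads alike. Also open, on these data alone, is whether a longer chain than ethyl, such as butyl, moves the number further.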